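Ester to acid: one ethyl removed on a shared core

The compounds below may be only part of what the source reports. "The series", "measured", "known", "first", "only" and "open" are said of these compounds alone.

The measured compounds:
compound 1 `CCOC(=O)/C(=C/C(=O)O)[C@H]1c2c(cc(O)c(O)c2O)C(=O)O[C@@H]1C(=O)OCC`, 10800 nM
compound 2 `CCOC(=O)/C=C(/C(=O)OCC)[C@H]1c2c(cc(O)c(O)c2O)C(=O)O[C@@H]1C(=O)OCC`, 2200 nM
compound 3 `CCOC(=O)C[C@@H](C(=O)OCC)[C@H]1c2c(cc(O)c(O)c2O)C(=O)O[C@@H]1C(=O)OCC`, 6800 nM

In a functional assay, with a stated time of 30 min (a lower number here means that less compound is needed, a higher number that more compound is needed for the effect), compound 2 and compound 1 differ only by hydrogen in place of ethyl on an oxygen next to a carbonyl group, and that change gave a 4.9-fold higher number from compound 2 to compound 1 (0.69 log units; beyond the scatter). Compound 3 carries a different core; how it differs from the core of compound 2 is not broken down here. Compound 4 `CCOC(=O)[C@H]1OC(=O)c2cc(O)c(O)c(O)c2[C@@H]1[C@@H](CC(=O)O)C(=O)OCC` is not yet measured and differs from compound 3 by hydrogen in place of ethyl on an oxygen next to a carbonyl group, the same change at the same kind of place. The expectation for compound 4 rests on the earlier step alone, so compound 4 is expected to show a 3.2-fold higher number from compound 3 to compound 4 (0.51 log units; beyond the scatter) in this assay. On that basis compound 4 is estimated at 22000 nM, with a range from 8000 nM to 60000 nM.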

Compound 4, half-maximal effective concentration: 8100 nM
Beside the measured number, compound 4's estimate is 2.7-fold (0.43 log units) above it; the range from low to high includes it.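

In this assay the change from ethoxycarbonyl to carboxy gave a 1.2-fold higher number from compound 3 to compound 4 (0.08 log units; within the scatter) on this core. Set beside the earlier case, the same change did not carry over at the same size from one core to the other: the same change on two cores in this assay, a 4.9-fold higher number (0.69 log units; beyond the scatter) from compound 2 to compound 1 and a 1.2-fold higher number (0.08 log units; within the scatter) from compound 3 to compound 4, 4.1-fold (0.62 log units) apart, beyond the scatter of two such steps. Among the compounds shown here, two cores are only two examples, and they show neither why the steps differ nor what the change would do on a further core.

The compounds shown leave open what a longer chain, such as propyl in place of ethyl, would give at this place. They also leave open whether an amide in place of the carboxy group would follow either step.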